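Sulfonamide Chalcone Analogues on Breast Cancer Cells

The source may hold more compounds than are shown below. What is called first, only, known or untested is meant among the compounds shown, and "the series" means these compounds.

Compound 1 `COc1cccc(C(=O)Nc2cccc(/C=C/C(=O)c3nc4ccccc4[nH]3)c2)c1` gives 17800 nM; compound 2 `COc1ccc(C(=O)Nc2cccc(/C=C/C(=O)c3nc4ccccc4[nH]3)c2)cc1` gives 20100 nM; compound 3 `Cc1cccc(S(=O)(=O)Nc2cccc(/C=C/C(=O)c3nc4ccccc4[nH]3)c2)c1` gives 886 nM; all in a functional assay on MCF7 cells (Homo sapiens) for antiproliferative activity, read by MTT assay, with a stated time of 48 h; a higher number here means a weaker inhibitor, a lower number a stronger inhibitor.

Compound 3 holds the lowest number of the three in this assay, and both of its steps from the other compounds are beyond the scatter: a 20-fold lower number from compound 1 to compound 3 (1.30 log units; beyond the scatter) and a 23-fold lower number from compound 2 to compound 3 (1.36 log units; beyond the scatter). Between the two carbonyl-linked compounds, the step of a 1.1-fold higher number from compound 1 to compound 2 (0.05 log units; within the scatter) is within the scatter.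

Compound 4 `Cc1ccc(S(=O)(=O)Nc2cccc(/C=C/C(=O)c3nc4ccccc4[nH]3)c2)cc1C` differs from compound 3 by one change: methyl in place of hydrogen on an aromatic carbon. The methyl enters on an aromatic carbon of a six-membered aromatic ring of carbon only, ortho to a methyl group and para to a large group, so that 3-methylphenyl becomes 3,4-dimethylphenyl.

Among the compounds with values here, none of the measured steps tests the addition of a methyl on this ring. Within the data shown here, the two large steps into compound 3 concern the exchange of a carbonyl linker for a sulfonyl linker, not the substitution pattern of the outer ring, and the one step that does move a substituent on that ring, from compound 1 to compound 2, stays within the scatter. On this evidence compound 4 is expected to land close to compound 3, with an estimated step of a 1.0-fold higher number from compound 3 to compound 4 (0.01 log units; within the scatter), not beyond the scatter. The estimate for compound 4 in this assay is 900 nM, within a range from 350 nM to 2300 nM.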

Compound 4, half-maximal inhibitory concentration: 5860 nM
Beside the measured number, compound 4's estimate is 6.5-fold (0.81 log units) below it; the measured number lies above the stated range.
By their numbers in this assay, from the lowest: compound 3; then compound 4; then compounds 1 and 2 (each within the scatter of the next).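

In this assay, the outer ring of the sulfonyl-linked compounds proves sensitive to a very small change: methyl in place of hydrogen, on the aromatic carbon ortho to a methyl group and para to a large group, gives a 6.6-fold higher number from compound 3 to compound 4 (0.82 log units; beyond the scatter). Within the data shown here, this is the first step on the outer ring to lie beyond the scatter, since the move of the methoxy group on the outer ring of the carbonyl-linked pair, a 1.1-fold higher number from compound 1 to compound 2 (0.05 log units; within the scatter), stayed within it, although that pair carries a different linker and a different substituent. The two steps therefore show that one added heavy atom on this ring can matter, but nothing given here explains why this change raises the number, and the finding rests on a single pair.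

The compounds shown leave open whether the step belongs to the new methyl alone or to its pairing with the methyl already on the ring, as 3,4-dimethylphenyl is the only such pattern here. They also leave open how a fluorine, an ethyl chain, an amine or a carboxylic acid would read at this same aromatic carbon.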